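The source may hold more compounds than are shown below. What is called first, only, known or untested is meant among the compounds shown, and "the series" means these compounds.

Working notes on the spiro series.

Two compounds of the series have numbers in an assay on HEK293 cells for displacement of a labelled ligand from NPC1-like intracellular cholesterol transporter 1 (Homo sapiens); on this read-out lower numbers stand for stronger inhibition and higher numbers for weaker inhibition. Compound 1 `CCC1CCCN(C(=O)CN2CN(c3ccccc3)C3(CCN(C(=O)c4ccc(C5CCCCC5)cc4)CC3)C2=O)C1` gives 2600 nM in this assay. Compound 2 `CC(C)(C)c1ccc(C(=O)N2CCC3(CC2)C(=O)N(CC(=O)N2CCN(S(C)(=O)=O)CC2)CN3c2ccccc2)cc1` gives 19000 nM in this assay, the highest of the two numbers; its nearest neighbour is compound 1, and the gap between the two lies beyond the scatter. Among the measured compounds shown here, compound 1 and compound 2 differ from each other in more than one place, so no single step connects them.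

Compound 3 `CC1CCCN(C(=O)CN2CN(c3ccccc3)C3(CCN(C(=O)c4ccc(C(C)(C)C)cc4)CC3)C2=O)C1` has not been measured in this assay. It differs from compound 2 in one place: 3-methylpiperidin-1-yl in place of 4-(methylsulfonyl)piperazin-1-yl on a carbonyl carbon. For the measured compounds named here, compound 1 and compound 3 share neither a single-point relation nor a measured step, so the only guide is the two values shown.

Compound 3 is expected to give 4500 nM in this assay, with a range from 1500 nM to 14000 nM. The expected step is a 4.2-fold lower number from compound 2 to compound 3 (0.63 log units; beyond the scatter), downward and beyond the scatter, but a step of no size beyond the scatter cannot be excluded.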

Compound 3, half-maximal inhibitory concentration: 12000 nM
Beside the measured number, compound 3's estimate is 2.7-fold (0.43 log units) below it, and the stated range covers the measured number.
By their numbers in this assay, from the lowest: compound 1; then compounds 3 and 2 (each within the scatter of the next).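

In this assay, among the compounds shown here, 3-methylpiperidin-1-yl in place of 4-(methylsulfonyl)piperazin-1-yl on a carbonyl carbon gives a 1.6-fold lower number from compound 2 to compound 3 (0.20 log units; within the scatter), the first single-point reading at this position, and the step does not separate the two groups. For the compounds shown here, the change takes the group from 10 heavy atoms to 7, removes a sulfur, a ring nitrogen and 2 hydrogen-bond acceptors, and still leaves the read-out within the scatter, so these differences in count and atom make-up register no measurable step here. No measurement available for this series offers a reason for this result.

Going by these compounds, it remains open whether any group on this carbonyl carbon can move the number beyond the scatter, for instance an open-chain dimethylamino group, a morpholin-4-yl ring, or a piperidine ring carrying a carboxylic acid. On these data alone, it is also open whether 3-methylpiperidin-1-yl and 4-(methylsulfonyl)piperazin-1-yl would stay within the scatter of each other if the rest of the molecule carried a different group.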